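Moving the Chlorine Around a Benzyl Ring

The compounds below may be only part of what the source reports. "The series", "measured", "known", "first", "only" and "open" are said of these compounds alone.

Compound 2 `COC(=O)[C@H](CCSC)NC(=O)c1ccc(NCc2cncn2Cc2ccc(Cl)cc2)cc1-c1ccccc1` was tested in a functional assay on NIH3T3 cells (Mus musculus); on this read-out lower numbers stand for an effect already at smaller amounts and higher numbers for an effect only at larger amounts of compound. In this assay compound 2 gives only a limit, > 10 uM, and no number. Compound 1 `CC(C)NC(=O)c1ccc(NCc2cncn2Cc2ccc(C#N)cc2)cc1-c1ccccc1`, which shares the core, likewise gives only a limit in this assay, > 10 uM. Compound 2 thus stands where every measured value of this set sits, at the limit of > 10 uM in this assay, at which 2 of the 2 values shown sit, with nothing to separate it from compound 1.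

Compound 3 `COC(=O)[C@H](CCSC)NC(=O)c1ccc(NCc2cncn2Cc2cccc(Cl)c2)cc1-c1ccccc1` has not yet been measured in this assay. It differs from compound 2 in one place: 3-chlorophenyl in place of 4-chlorophenyl on a saturated chain carbon bound to an aromatic nitrogen. For the measured compounds named here, no step between two measured compounds is known here, so there is no measured change to lean on. Because compound 2 sits at the limit of > 10 uM in this assay, at which 2 of the 2 values shown sit, the step from compound 2 to compound 3 is expected to be small, a step that the limit leaves unreadable from compound 2 to compound 3, with no direction preferred beyond the scatter. Compound 3 is therefore expected to give about 15 uM in this assay, within a range from 5 uM to 50 uM, most likely again reported only as a limit.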

Compound 3, concentration for half-maximal effect: > 10 uM
Compound 3: a limit, no number; the forecaster's own chance of this, stated with the estimate: 75%; the middle value lies beyond the limit too.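

In this assay compound 3 gives > 10 uM as a limit and not a number. Compound 2 likewise gives only a limit, so no step can be read between compound 2 and compound 3: the limit of > 10 uM in this assay, at which 3 of the 3 values shown sit.

The compounds shown leave open whether 3-chlorophenyl in place of 4-chlorophenyl changes the result in this assay at all.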